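This account rests on a few compounds, and the source may have more. Where it says the series, first, only, none or still open, it means among the compounds named here.

Measured compounds:
- compound 1, `O[C@H](COCCOC[C@@H](O)Cc1cn(-c2cccnc2)nn1)Cc1ccc(-c2ccccc2)cc1`, in a functional assay on HCT-116 cells (Homo sapiens) for inhibition, read by MTT assay, with a stated time of 72 h (on this read-out higher numbers stand for weaker inhibition of growth and lower numbers for stronger inhibition of growth), compound 1 gives 46800 nM
- compound 2, `O[C@H](COCCOC[C@@H](O)Cc1cn(Cc2ccc(C(F)(F)F)cc2)nn1)Cc1ccc(-c2ccccc2)cc1`, in this assay compound 2 gives 2500 nM

Among the measured compounds shown here, compound 2 stands at the lowest of the two numbers so far; its nearest neighbour is compound 1, and the single measured step, a 19-fold lower number from compound 1 to compound 2 (1.27 log units; beyond the scatter), separates them, with 4-(trifluoromethyl)benzyl in place of pyridin-3-yl on an aromatic nitrogen.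

Compound 3, `O[C@H](COCCOC[C@@H](O)Cc1cn(-c2ccc3[nH]ccc3c2)nn1)Cc1ccc(-c2ccccc2)cc1`, has not yet been measured. It differs from compound 2 in one place: 1H-indol-5-yl in place of 4-(trifluoromethyl)benzyl on an aromatic nitrogen. For the measured compounds named here, the only step that bears on this change is the one from compound 1 to compound 2, and it was large. Compound 3 shares with compound 1 a group bound through an aromatic ring to that nitrogen, rather than the 4-(trifluoromethyl)benzyl of compound 2, so a step back toward the number of compound 1 is expected, though the indol-5-yl group is not the pyridin-3-yl of compound 1 and the size of that step is uncertain. The expected step is a 6.0-fold higher number from compound 2 to compound 3 (0.78 log units; beyond the scatter). Compound 3 is therefore estimated at 15000 nM, with a range from 4000 nM to 50000 nM.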

Compound 3, concentration for 50% growth inhibition: 15500 nM
The estimate for compound 3 lay 1.0-fold (0.01 log units) below the measured number; the measured number falls inside the stated range.
By their numbers in this assay, from the lowest: compound 2; then compound 3; then compound 1.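

The new compound shows that a group bound through an aromatic ring to this nitrogen does not fix the number at the level of compound 1. In this assay, 1H-indol-5-yl in place of pyridin-3-yl gives a 3.0-fold lower number from compound 1 to compound 3 (0.48 log units; beyond the scatter), so the identity of the aromatic group matters at this position, on a five-membered aromatic ring with 3 nitrogen. That gain does not match 4-(trifluoromethyl)benzyl, however: 1H-indol-5-yl in its place gives a 6.2-fold higher number from compound 2 to compound 3 (0.79 log units; beyond the scatter), which leaves compound 2 with the strongest inhibition of growth among the three and places compound 3 between the other two.

No measured evidence explains the order of these three groups. The compounds shown also cannot separate the contribution of the benzyl link from that of the trifluoromethyl group, since compound 2 differs from compound 1 and compound 3 in both; a plain benzyl or a 4-(trifluoromethyl)phenyl group on the same nitrogen would bear directly on that question.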